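A few compounds are considered here, and "the series" means these few. Any claim that something is new, unique, unknown or untested is made for them only; others in the source may bear on it.

Measured so far:
- compound 1, `O=c1ccc2ccc(OCc3cn(-c4cccc(S(=O)(=O)N5CCc6ccccc6C5)c4)nn3)cc2o1`, 91500 nM
- compound 2, `COc1cc2c(cc1OC)CN(S(=O)(=O)c1cccc(-n3cc(COc4ccc5ccc(=O)oc5c4)nn3)c1)CC2`, > 50000 nM, which is a limit of the assay
- compound 3, `COc1cc2c(cc1OC)CN(S(=O)(=O)c1ccc(-n3cc(COc4ccc([N+](=O)[O-])cc4)nn3)cc1)CC2`, > 50000 nM, likewise a limit of the assay

All three were run in an ADME assay on Vero cells (Chlorocebus sabaeus) for cytotoxicity, read by fluorescence, with a stated time of 4 days; a lower number here means a stronger inhibitor, a higher number a weaker inhibitor. Compound 1 gives a number, whereas compound 3 stands at the limit of > 50000 nM in this assay, at which 2 of the 3 values shown sit, so only a bound is known for it. Compound 4, `COc1cc2c(cc1OC)CN(S(=O)(=O)c1ccc(-n3cc(COc4ccccc4C(C)=O)nn3)cc1)CC2`, has not been measured; it differs from compound 3 by 2-acetylphenyl in place of 4-nitrophenyl on an oxygen on a saturated carbon. For the measured compounds named here, no measured pair shows this change, so the step is expected to be small and within the scatter, in no set direction. Compound 4 is therefore estimated at 80000 nM, between 40000 nM and 200000 nM, and most likely again reported only as a limit. The expected step is a step that the limit leaves unreadable from compound 3 to compound 4.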

Compound 4, half-maximal inhibitory concentration: 37200 nM
Estimate against measurement, compound 4: 2.2-fold (0.33 log units) above; the whole stated range lies above it.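

In this assay, 2-acetylphenyl in place of 4-nitrophenyl on an oxygen on a saturated carbon brings an at least 1.3-fold lower number from compound 3 to compound 4 (0.12 log units; that floor lies within the scatter). This position can therefore yield a measured number, though that floor alone does not separate the two groups. The full size of the step stays unknown, because compound 3 is known only through a limit: the limit of > 50000 nM in this assay, at which 2 of the 4 values shown sit.

The compounds shown leave open whether the true step lies beyond the scatter. They also leave open how an amine or a carboxylic acid would read in place of the acetyl group.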